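A few compounds are considered here, and "the series" means these few. Any claim that something is new, unique, unknown or untested is made for them only; others in the source may bear on it.

Values in a functional assay on NCI-H1975 cells (Homo sapiens) for antiproliferative activity, read by MTT assay, with a stated time of 72 h (a higher number here means a weaker inhibitor, a lower number a stronger inhibitor), follow.

- compound 1 `C=C(F)C(=O)Nc1cc(Nc2nccc(-c3cn(C)c4ccccc34)n2)c(OC)cc1N(C)CCN(C)C` gives 4230 nM
- compound 2 `C=C(Cl)C(=O)Nc1cc(Nc2nccc(-c3cn(C)c4ccccc34)n2)c(OC)cc1N(C)CCN(C)C` gives 1290 nM
- compound 3 `COc1cc(N(C)CCN(C)C)c(NC(=O)C=C(C)C)cc1Nc1nccc(-c2cn(C)c3ccccc23)n1` gives 5610 nM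

Compound 2 has the lowest number of the three, and both of its steps to the others lie beyond the scatter. Compound 4 `COc1cc(N(C)CCN(C)C)c(NC(=O)/C=C\C(C)C)cc1Nc1nccc(-c2cn(C)c3ccccc23)n1` carries 3-methylbut-1-en-1-yl in place of 1-chloroethenyl on a carbonyl carbon. The closest measured change puts 2-methylprop-1-en-1-yl in that same place (a 4.3-fold higher number from compound 2 to compound 3 (0.64 log units; beyond the scatter)). The step between the two halogen-bearing compounds (a 3.3-fold lower number from compound 1 to compound 2 (0.52 log units; beyond the scatter)) shows that the chloro compound leads, while the remaining step (a 1.3-fold higher number from compound 1 to compound 3 (0.12 log units; within the scatter)) is within the scatter. A rise of similar size is therefore expected in this assay (a 3.1-fold higher number from compound 2 to compound 4 (0.49 log units; beyond the scatter)). For compound 4 the estimated value is 4000 nM, with an expected range from 1600 nM to 10000 nM.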

Compound 4, half-maximal inhibitory concentration: 1820 nM
Beside the measured number, compound 4's estimate is 2.2-fold (0.34 log units) above it; measured number inside the range.
By their numbers in this assay, from the lowest: compounds 2 and 4 (each within the scatter of the next); then compounds 1 and 3 (each within the scatter of the next).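

In this assay, a chlorine on the chain is not needed for a low number at this position: 3-methylbut-1-en-1-yl, which holds only carbon, matches 1-chloroethenyl within the scatter (a 1.4-fold higher number from compound 2 to compound 4 (0.15 log units; within the scatter)). Changing the carbon chain alone also matters, since 3-methylbut-1-en-1-yl gives a clearly lower number than 2-methylprop-1-en-1-yl (a 3.1-fold lower number from compound 3 to compound 4 (0.49 log units; beyond the scatter)) and than 1-fluoroethenyl (a 2.3-fold lower number from compound 1 to compound 4 (0.37 log units; beyond the scatter)). No measurement available here explains these steps. On these data alone, how a longer chain, or a chain carrying an amine, would behave on this carbonyl carbon remains open.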